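Clearance notes on the ring amine nitrogen group

The source may hold more compounds than are shown below. What is called first, only, known or untested is meant among the compounds shown, and "the series" means these compounds.

Measured in an ADME assay on the whole organism (Rattus norvegicus, strain Sprague-Dawley) for pharmacokinetics, read by LC-MS, at a dose of 1 mg/kg by the intravenous route; on this read-out higher numbers stand for fast clearance and lower numbers for slow clearance:
- compound 1 `Cc1cccc(F)c1CN1CCc2cc(-c3c(C)nc(C)c([C@H](OC(C)(C)C)C(=O)O)c3N3CCC(C)(C)CC3)ccc2C1`: 5.8 mL/min/kg
- compound 2 `Cc1nc(C)c([C@H](OC(C)(C)C)C(=O)O)c(N2CCC(C)(C)CC2)c1-c1ccc2c(c1)CCN(c1ncnc3c1cnn3C)C2`: 3.6 mL/min/kg

Within the data shown here, compound 2 stands at 3.6 mL/min/kg in this assay, within the scatter of the only other measured compound. Compound 3 `Cc1nc(C)c([C@H](OC(C)(C)C)C(=O)O)c(N2CCC(C)(C)CC2)c1-c1ccc2c(c1)CCN(c1nccc(-c3cnccn3)n1)C2` has not yet been measured. It departs from compound 2 at one place: a group of 12 heavy atoms (8 carbon, 4 nitrogen; 2 six-membered aromatic rings with 2 hetero atoms each) in place of a group of 10 heavy atoms (6 carbon, 4 nitrogen; one five-membered aromatic ring with 2 hetero atoms, one six-membered aromatic ring with 2 hetero atoms), on an amine nitrogen in a ring. The shared core stays the same.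

Among the measured compounds shown here, only one measured step bears on this change, and it sits at the same amine nitrogen: a 1.6-fold lower number from compound 1 to compound 2 (0.21 log units; within the scatter). For the measured compounds named here, it is a single step, and no measured compound carries the entering group, so the guidance is thin. No shift beyond the scatter is expected in this assay, and no direction can be called with confidence. The expected size is a 1.2-fold higher number from compound 2 to compound 3 (0.07 log units; within the scatter). Compound 3 is estimated at 4.2 mL/min/kg, with an expected range of 2 mL/min/kg to 8.5 mL/min/kg.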

Compound 3, clearance: 2.1 mL/min/kg
Beside the measured number, compound 3's estimate is 2.0-fold (0.30 log units) above it, and the stated range covers the measured number.
By their numbers in this assay, from the lowest: compounds 3, 2 and 1 (each within the scatter of the next, the first and the last beyond it).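

In this assay, the step of a 1.7-fold lower number from compound 2 to compound 3 (0.23 log units; within the scatter) leaves the two groups on the amine nitrogen in a ring indistinguishable, so the group with 2 six-membered aromatic rings with 2 hetero atoms each reads the same as the fused five- and six-membered group. Among these compounds, the new information is a 2.8-fold lower number from compound 1 to compound 3 (0.44 log units; beyond the scatter), the first step at this position to lie beyond the scatter, whereas compound 2 and compound 1 remain within the scatter of each other. No measurement shown accounts for this step.

Still open, on these data alone, is how a non-aromatic group on this nitrogen, such as an acetyl group or a plain alkyl chain, would read. Also open, as far as these compounds go, is whether a single aromatic ring with hetero atoms would suffice there.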